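Replacing a Cyclohexyl Amide Arm on a Sulfated Sugar

A few compounds are considered here, and "the series" means these few. Any claim that something is new, unique, unknown or untested is made for them only; others in the source may bear on it.

compound 1 `CO[C@H]1O[C@H](CNC(=O)CN(CCOS(=O)(=O)O)C(C)=O)[C@@H](OS(=O)(=O)O)[C@H](OS(=O)(=O)O)[C@@H]1OS(=O)(=O)O`: 95000 nM
compound 2 `CO[C@H]1O[C@H](CNC(=O)CN(C(C)=O)C2CCCCC2)[C@@H](OS(=O)(=O)O)[C@H](OS(=O)(=O)O)[C@@H]1OS(=O)(=O)O`: 310000 nM

In an assay on isolated protein for binding affinity to fibroblast growth factor 1 (Homo sapiens), read by surface plasmon resonance (a lower number here means tighter binding, a higher number weaker binding), compound 1 gives 95000 nM, while compound 2 gives 310000 nM. Compound 2 therefore holds the higher of the two numbers, with a 3.3-fold higher number from compound 1 to compound 2 (0.51 log units; beyond the scatter) separating it from compound 1. Compound 3 `CCN(CC(=O)NC[C@H]1O[C@H](OC)[C@@H](OS(=O)(=O)O)[C@@H](OS(=O)(=O)O)[C@@H]1OS(=O)(=O)O)C(=O)CCCCC(=O)O` carries ((4-carboxybutyl)carbonyl)(ethyl)amino in place of acetyl(cyclohexyl)amino on a saturated chain carbon bound to a carbonyl carbon. Within the data shown here, only that one measured step bears on this change, and it ran the opposite way, trading an open chain for the ring that now departs. On that basis the expected step is a 2.6-fold lower number from compound 2 to compound 3 (0.41 log units; beyond the scatter), a modest lowering. Compound 3 is estimated at 120000 nM in this assay, with a range from 40000 nM to 400000 nM.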

Compound 3, dissociation constant: 160000 nM
The estimate for compound 3 lay 1.3-fold (0.12 log units) below the measured number; measured number inside the range.
By their numbers in this assay, from the lowest: compounds 1, 3 and 2 (each within the scatter of the next, the first and the last beyond it).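

In this assay, the ((4-carboxybutyl)carbonyl)(ethyl)amino arm brings a 1.9-fold lower number from compound 2 to compound 3 (0.29 log units; within the scatter) and a 1.7-fold higher number from compound 1 to compound 3 (0.23 log units; within the scatter). On a saturated chain carbon bound to a carbonyl carbon, this ring-free arm therefore cannot be told apart from either the acetyl(cyclohexyl)amino arm or the acetyl(2-(sulfooxy)ethyl)amino arm, even though those two differ beyond the scatter. Nothing available explains this result.

From the compounds shown here alone, it remains open whether an amine in place of the carboxylic acid, or a longer chain carrying that acid, would separate from these arms.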